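The source may hold more compounds than are shown below. What is called first, only, known or untested is meant among the compounds shown, and "the series" means these compounds.

Working notes on the series. Compound 1 `CCOC(=O)CCO/N=C(/c1ccc(OC)c(OC)c1OC)c1cccc2ccccc12` in a functional assay on MCF7 cells (Homo sapiens) for inhibition, read by sulforhodamine B assay, with a stated time of 48 h (a higher number here means a weaker inhibitor, a lower number a stronger inhibitor), gives only a limit of the assay, > 20000 nM, which is the limit of > 20000 nM in this assay, at which 1 of the 2 values shown sits. Compound 2 `COc1ccc(C(c2ccc(OC(C)CN(C)C)cc2)c2cccc3ccccc23)c(OC)c1OC` in this assay gives 13100 nM. Compound 1 thus has no number of its own and stands at the limit, the weaker end of what has been measured. Compound 3 `CCOC(=O)CO/N=C(/c1ccc(OC)c(OC)c1OC)c1cccc2ccccc12` differs from compound 1 by ethoxycarbonyl in place of (ethoxycarbonyl)methyl on a saturated chain carbon bound to an oxygen on an unsaturated carbon. Within the data shown here, no measured pair shows this change, and in this assay no step beyond the scatter is expected from it. Compound 3 is therefore expected to give about 25000 nM, between 8000 nM and 80000 nM. The expected step that the limit leaves unreadable from compound 1 to compound 3 stays within the scatter.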

Compound 3, half-maximal inhibitory concentration: > 20000 nM
Compound 3: no number, only a limit (the forecaster's own chance of this, stated with the estimate: 70%); the middle value lies beyond the limit too.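

No step can be read between compound 1 and compound 3, since both give only a limit in this assay: the limit of > 20000 nM in this assay, at which 2 of the 3 values shown sit.

On these data alone, whether ethoxycarbonyl and (ethoxycarbonyl)methyl at this place differ at all in this assay stays open.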